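Swapping fluoro for chloro in a small, flat series

The compounds below may be only part of what the source reports. "The series", "measured", "known", "first", "only" and "open" are said of these compounds alone.

Three close relatives share one core and differ only in a substituted phenyl group. In a functional assay on HL-60 cells (Homo sapiens) for cytotoxicity, read by WST assay, with a stated time of 48 h (on this read-out higher numbers stand for an effect only at larger amounts of compound and lower numbers for an effect already at smaller amounts), compound 1 (`O=C1OC[C@H](Cc2ccccc2)[C@H]1Cc1cccc(Cl)c1`) gives 36000 nM, compound 2 (`Cc1ccc(C[C@H]2C(=O)OC[C@@H]2Cc2ccccc2)cc1`) gives 44000 nM, and compound 3 (`O=C1OC[C@H](Cc2ccccc2)[C@H]1Cc1ccc(F)cc1`) gives 57000 nM. These numbers cannot really be told apart: the data show a 1.3-fold higher number from compound 2 to compound 3 (0.11 log units; within the scatter) and a 1.6-fold higher number from compound 1 to compound 3 (0.20 log units; within the scatter), so compound 3 stands level with the other two.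

Compound 4 (`O=C1OC[C@H](Cc2ccccc2)[C@H]1Cc1ccc(Cl)cc1`) differs from compound 3 in one place: chloro in place of fluoro on an aromatic carbon. In words, this is chloro in place of fluoro on an aromatic carbon, turning 4-fluorophenyl into 4-chlorophenyl.

For the measured compounds named here, no measured pair makes exactly this swap, so the neighbouring steps have to serve as a guide. Exchanging the group at that same place gave a 1.3-fold higher number from compound 2 to compound 3 (0.11 log units; within the scatter), and moving from the 3-chlorophenyl of compound 1 to the 4-methylphenyl of compound 2 gave a 1.2-fold higher number from compound 1 to compound 2 (0.09 log units; within the scatter). Every step in this small set stays within the scatter, so no step beyond the scatter is expected in this assay for this swap. The expected step is only a 1.3-fold lower number from compound 3 to compound 4 (0.10 log units; within the scatter). Compound 4 is estimated at 45000 nM, with an expected range from 24000 nM to 85000 nM.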

Compound 4, half-maximal effective concentration: 36000 nM
For compound 4 the middle estimate is 1.3-fold (0.10 log units) above the measured one, and the stated range covers the measured number.
By their numbers in this assay, from the lowest: compounds 1, 4, 2 and 3 (each within the scatter of the next).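

For the compounds shown here, replacing 4-fluorophenyl with 4-chlorophenyl gives a 1.6-fold lower number from compound 3 to compound 4 (0.20 log units; within the scatter) in this assay and stays within the scatter, so this is the first direct evidence that exchanging these two halogens on an aromatic carbon, para to a large group, does not measurably shift the read-out. Chloro in place of methyl on that same carbon gives a 1.2-fold lower number from compound 2 to compound 4 (0.09 log units; within the scatter) and also cannot be told apart from no change, while 4-chlorophenyl in place of 3-chlorophenyl gives no change at the digits printed from compound 1 to compound 4 (within the scatter) and so adds a first comparison of these two chlorinated phenyl groups, which show no difference here. No other measurement bears on why these swaps leave the numbers level.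

The compounds shown carry only chloro, fluoro or methyl on this phenyl group, so it remains open whether an amine, a carboxylic acid or a longer chain there would produce a step beyond the scatter. Also open, going by these compounds, is what would happen if the other phenyl group, common to all four compounds, carried any of these groups.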